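Shifting the trifluoromethyl Group Around the Benzyl Ring

This account rests on a few compounds, and the source may have more. Where it says the series, first, only, none or still open, it means among the compounds named here.

Compound 1 `COc1ccc([C@@H]2CC(=O)c3c(O)cc(OCc4cn(Cc5cccc(C(F)(F)F)c5)nn4)cc3O2)cc1O` and compound 2 `COc1ccc([C@@H]2C/C(=N\O)c3c(O)cc(OCc4cn(-c5ccccc5)nn4)cc3O2)cc1O` have both been tested in a functional assay on RAW264.7 cells (Mus musculus) for inhibition, read by Griess assay, with stated times of 2 h and 24 h; a higher number here means a weaker inhibitor, a lower number a stronger inhibitor. Compound 1 gives 19900 nM, the higher of the two numbers, while compound 2 gives 6130 nM; compound 1 thus stands as the weaker inhibitor of the pair, and the gap between them lies beyond the scatter. Compound 3 `COc1ccc([C@@H]2CC(=O)c3c(O)cc(OCc4cn(Cc5ccc(C(F)(F)F)cc5)nn4)cc3O2)cc1O` has not yet been measured. It differs from compound 1 only in the change 4-(trifluoromethyl)phenyl in place of 3-(trifluoromethyl)phenyl on a saturated chain carbon bound to an aromatic nitrogen: the same atoms, joined differently. Among the compounds with values here, no step between measured compounds covers a change of this kind, so there is nothing to lean on beyond the value of compound 1. The rearrangement is expected to move the number little, most likely within the scatter and with no clear direction, so the expected step of a 1.3-fold lower number from compound 1 to compound 3 (0.12 log units; within the scatter) is small. Compound 3 is estimated at 15000 nM, with a range from 6000 nM to 40000 nM.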

Compound 3, half-maximal inhibitory concentration: 17700 nM
Beside the measured number, compound 3's estimate is 1.2-fold (0.07 log units) below it; the measured number falls inside the stated range.
By their numbers in this assay, from the lowest: compound 2; then compounds 3 and 1 (each within the scatter of the next).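

In this assay, the rearrangement from 3-(trifluoromethyl)benzyl to 4-(trifluoromethyl)benzyl gives a 1.1-fold lower number from compound 1 to compound 3 (0.05 log units; within the scatter), so the two placements of the trifluoromethyl group cannot be told apart by this measurement. Within the data shown here, this is the first comparison of compounds that differ in one place, and it concerns the group on a saturated chain carbon bound to an aromatic nitrogen. No measurement on hand offers an explanation for this result.

The compounds shown leave open whether a different group on this benzyl ring, such as a nitrile, an amine or a carboxylic acid, would give a number beyond the scatter from that of compound 1. They also leave open how a longer chain in place of the benzyl carbon would read in this assay.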